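The source may hold more compounds than are shown below. What is called first, only, known or untested is meant among the compounds shown, and "the series" means these compounds.

Measured compounds:
- compound 1 `CC(C)(C)c1cc(NC(=O)Nc2cccc(Oc3ccnc4[nH]c(=O)cnc34)c2)n(-c2ccccc2)n1`: 1.4 h
- compound 2 `Cc1nc2c(Oc3ccc(NC(=O)Nc4cc(C(F)(F)F)ccc4F)c4ccccc34)ccnc2[nH]c1=O`: 6 h
- compound 3 `CSc1cc(Oc2ccnc3[nH]c(=O)cnc23)ccc1NC(=O)Nc1cc(C(C)(C)C)nn1-c1ccc(C)cc1`: 7.9 h

In an in vivo ADME assay on the whole organism (strain C57BL/cAnNCrl) for metabolic stability, with Mus musculus as the target, at a dose of 10 mg/kg by the oral route (a lower number here means that the compound disappears faster, a higher number that the compound lasts longer), compound 1 gives the lowest of the three half-lives; its nearest neighbour is compound 2, and its furthest is compound 3, both beyond the scatter.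

Compound 4 `Cc1ccc(-n2nc(C(C)(C)C)cc2NC(=O)Nc2cccc(Oc3ccnc4[nH]c(=O)cnc34)c2)cc1` is not yet measured. It differs from compound 1 by methyl in place of hydrogen on an aromatic carbon. Within the data shown here, no pair of measured compounds differs by this change alone, so no step is available; compound 3 also carries the 4-methylphenyl group but differs in other places too, and only its value can be noted.

For compound 4 a modest upward step from compound 1 is expected, a 1.6-fold higher number from compound 1 to compound 4 (0.20 log units; within the scatter), of a size that may not exceed the scatter. The estimated half-life of compound 4 in this assay is 2.2 h, within 1 h to 5 h.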

Compound 4, half-life: 4 h
Beside the measured number, compound 4's estimate is 1.8-fold (0.26 log units) below it, and the stated range covers the measured number.
By their numbers in this assay, from the lowest: compound 1; then compounds 4, 2 and 3 (each within the scatter of the next).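

In this assay, among these compounds, the change from phenyl to 4-methylphenyl gives a 2.9-fold higher number from compound 1 to compound 4 (0.46 log units; beyond the scatter) and this is the first reading of a single change. A lone methyl on this aromatic carbon, para to a large group, is therefore enough to move the half-life beyond the scatter. Nothing on hand accounts for the step.

Whether the step is specific to methyl remains open, as a methoxy group, an ethyl group or an amine at this carbon is not among the compounds shown. Whether it carries over to other substitution patterns on the core also remains unresolved.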